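Methyl for ethyl on a core nitrogen of compound 1

The source may hold more compounds than are shown below. What is called first, only, known or untested is meant among the compounds shown, and "the series" means these compounds.

Compound 1 `CCCn1c(=O)c2[nH]c(-c3ccc(S(=O)(=O)N4CCN(c5ccc(Cl)cc5)CC4)cc3)nc2n(CC)c1=O` has been measured in an assay on CHO cells for displacement of a labelled ligand from adenosine receptor A3 (Homo sapiens), read by scintillation counting, with a stated time of 45 min, in the presence of a further agent that is not named here; on this read-out lower numbers stand for stronger inhibition and higher numbers for weaker inhibition; in this assay compound 1 gives only the limit > 1000 nM and no number. Compound 2 `CCCn1c(=O)[nH]c2nc(-c3ccc(S(=O)(=O)N4CCN(c5ccccc5Br)CC4)cc3)[nH]c2c1=O` likewise gives only the limit > 1000 nM in this assay. Compound 3 `CCCn1c(=O)[nH]c2nc(-c3ccc(S(=O)(=O)N4CCN(c5cccc(F)c5)CC4)cc3)[nH]c2c1=O` also reaches only the limit > 1000 nM in this assay. The step that the two limits leave unreadable from compound 2 to compound 3 is thus unreadable; all three values sit at one limit (the limit of > 1000 nM in this assay, at which 3 of the 3 values shown sit). Compound 4 `CCCn1c(=O)c2[nH]c(-c3ccc(S(=O)(=O)N4CCN(c5ccc(Cl)cc5)CC4)cc3)nc2n(C)c1=O` differs from compound 1 by hydrogen in place of methyl on a saturated chain carbon bound to an aromatic nitrogen. Among the measured compounds shown here, no measured step bears on this change, and compound 1 itself has no number, so no size or direction can be drawn from the data for this assay. Compound 4 is expected to remain near the limit, with an estimate of 3000 nM, within 1000 nM to 10000 nM, an expected step that the limit leaves unreadable from compound 1 to compound 4.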

Compound 4, inhibition constant: > 1000 nM
Compound 4: no number, only a limit; the forecaster's own chance of this, stated with the estimate: 85%; the middle value is on the limit's open side.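

Compound 1 and compound 4 each give only a limit in this assay, so no step can be read between them: the limit of > 1000 nM in this assay, at which 4 of the 4 values shown sit.

The compounds shown leave open what size of effect, if any, the ethyl to methyl change has on the inhibition constant.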